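Clearance notes: changing the amide chain of compound 1

The source may hold more compounds than are shown below. What is called first, only, known or untested is meant among the compounds shown, and "the series" means these compounds.

- compound 1 `CC(C)(CO)CNC(=O)c1cc2cc(C#N)ccc2n1Cc1cccc(OC(F)(F)F)c1` at 20 mL.min-1.g-1
- compound 2 `COc1ccc(OC(F)(F)F)cc1Cn1c(C(=O)NCC(C)(C)CO)cc2cc(C#N)ccc21` at 31 mL.min-1.g-1

Both values come from an in vitro ADME assay on microsomes from liver (Homo sapiens) for metabolic stability, in the presence of a further agent that is not named here (on this read-out lower numbers stand for slow clearance and higher numbers for fast clearance), and lie within the scatter of each other, so compound 1 holds no separate place on these numbers. Compound 3 `N#Cc1ccc2c(c1)cc(C(=O)NCCC1(O)CCC1)n2Cc1cccc(OC(F)(F)F)c1` is still unmeasured. The change from compound 1 is (1-hydroxycyclobutyl)methyl in place of 1-(hydroxymethyl)-1-methylethyl on a saturated chain carbon bound to an amide-type nitrogen and it brings in one four-membered non-aromatic ring of carbon only, on a saturated chain carbon bound to an amide-type nitrogen.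

For the measured compounds named here, only one measured step exists, a 1.6-fold higher number from compound 1 to compound 2 (0.19 log units; within the scatter), a methoxy in place of hydrogen on an aromatic carbon. Going by the values given here, that step is not a change on the chain, so it bears on this swap only indirectly, and no measured step covers the swap itself. The series therefore gives no ground for a step beyond the scatter in this assay, in either direction. The expected move is a 1.1-fold higher number from compound 1 to compound 3 (0.04 log units; within the scatter) and it is taken as no real change. For compound 3 the estimate is 22 mL.min-1.g-1, with an expected range from 11 mL.min-1.g-1 to 40 mL.min-1.g-1 as the outer ends.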

Compound 3, intrinsic clearance in microsomes: < 6 mL.min-1.g-1
Compound 3: no number, only a limit (the forecaster's own chance of this, stated with the estimate: 5%); middle value at least 3.6-fold (0.56 log units) from the limit.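

In this assay the amide chain turns out to be a place where a single change moves the read-out beyond the scatter, with (1-hydroxycyclobutyl)methyl in place of 1-(hydroxymethyl)-1-methylethyl giving an at least 3.3-fold lower number from compound 1 to compound 3 (0.52 log units; beyond the scatter). For the compounds shown here, the only earlier step, a 1.6-fold higher number from compound 1 to compound 2 (0.19 log units; within the scatter), sat on an aromatic carbon and showed nothing about this position, so compound 3 is the first sign that clearance responds to the chain on the amide-type nitrogen. The read-out for compound 3 is a limit of the assay and not a number, so the step has a known minimum but no known size: the limit of < 6 mL.min-1.g-1 in this assay, at which 1 of the 3 values shown sits.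

The two chains differ in more than the four-membered ring, and the compounds shown do not tell whether the ring alone accounts for the step, or whether a five-membered non-aromatic ring of carbon only, a longer chain or an amine in place of the hydroxy group would hold the read-out at this level. Also open, on these data alone, is whether the same swap on compound 2, with its methoxy group, would give a step of similar size.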